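Swapping the Aromatic Substituent Toward Compound 3

The compounds below may be only part of what the source reports. "The series", "measured", "known", "first", "only" and "open" are said of these compounds alone.

Measured so far in an assay on RBE4 cells for inhibition of Monocarboxylate transporter 1 (Rattus norvegicus), with a stated time of 15 min; a higher number here means a weaker inhibitor, a lower number a stronger inhibitor:
compound 1 `CCc1ccc(/C=C(\C#N)C(=O)O)cc1`: 500 nM
compound 2 `N#C/C(=C\c1ccc([N+](=O)[O-])cc1)C(=O)O`: 500 nM

Going by the values given here, compound 2 stands level with compound 1 on the only value shown, and the step of no change at the digits printed from compound 1 to compound 2 (within the scatter) lies within the scatter. Compound 3 `N#C/C(=C\c1ccc(N2CCCCC2)cc1)C(=O)O` carries the change (piperidin-1-yl in place of nitro on an aromatic carbon). Among the compounds with values here, only that one measured step bears on this change, and it showed no movement, so no shift beyond the scatter is expected in this assay. The step of no change at the digits printed from compound 2 to compound 3 (within the scatter) is therefore estimated as no change. Compound 3 is expected to give about 500 nM, with a range from 150 nM to 1600 nM.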

Compound 3, half-maximal inhibitory concentration: 140 nM
Beside the measured number, compound 3's estimate is 3.6-fold (0.55 log units) above it, outside the stated range (below it).
By their numbers in this assay, from the lowest: compound 3; then compounds 1 and 2 (each within the scatter of the next).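

In this assay, the aromatic carbon carrying these groups proves sensitive to its substituent: piperidin-1-yl in place of nitro gives a 3.6-fold lower number from compound 2 to compound 3 (0.55 log units; beyond the scatter), and piperidin-1-yl in place of ethyl gives a 3.6-fold lower number from compound 1 to compound 3 (0.55 log units; beyond the scatter). The earlier pair, with nitro and ethyl, had shown no movement, so this is the first change here to go beyond the scatter. Nothing available explains why piperidin-1-yl differs from the other two groups. The compounds shown leave open whether the six-membered ring itself matters, or whether an open-chain amine such as dimethylamino would give a similar number.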